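The source may report more compounds than this note shows. Statements on the series, on what has been measured and on what is new or still open speak of the compounds shown alone.

In an ADME assay on HaCaT cells (Homo sapiens) for cytotoxicity, read by MTT assay, with a stated time of 48 h (a higher number here means a weaker inhibitor, a lower number a stronger inhibitor), three compounds that share one core have been measured so far. Compound 1 (`Fc1ccc(-c2nn(-c3ccccc3)cc2-c2nc3ccccc3[nH]2)cc1`) gives > 50000 nM, which is a limit of the assay and not a number. Compound 2 (`Fc1ccc(-c2nn(-c3ccccc3)cc2-c2nc3cc(Cl)ccc3[nH]2)cc1`) gives > 50000 nM, again a limit. Compound 3 (`Cc1ccc2[nH]c(-c3cn(-c4ccccc4)nc3-c3ccc(F)cc3)nc2c1`) gives > 50000 nM, also a limit, so it holds no position of its own among the others. The whole set rests on the limit of > 50000 nM in this assay, at which 3 of the 3 values shown sit, and offers no exact value.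

Compound 4 (`COc1ccc(-c2nn(-c3ccccc3)cc2-c2nc3cc(C)ccc3[nH]2)cc1`) has methoxy in place of fluoro on an aromatic carbon, para to a large group (methoxy in place of fluoro on an aromatic carbon). The same difference can be read as 4-fluorophenyl to 4-methoxyphenyl.

The measured steps offer only indirect guidance, since all of them involve a different group. Chloro in place of hydrogen gave a step that the two limits leave unreadable from compound 1 to compound 2 as its result. Methyl in place of hydrogen gave a step that the two limits leave unreadable from compound 1 to compound 3 as its result. Methyl in place of chloro gave a step that the two limits leave unreadable from compound 2 to compound 3 as its result. None of these sizes can be read, and none of them replaces the fluoro group.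

The expectation therefore rests on the shared limit, and no step beyond the scatter is foreseen in either direction. The expected change is a number no higher from compound 3 to compound 4 (the limit leaves the size open) in this estimate. For compound 4 the estimated value is 50000 nM, with an expected range from 20000 nM to 100000 nM, and another limit is the likeliest report.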

Compound 4, half-maximal inhibitory concentration: > 50000 nM
Compound 4: no number, only a limit (the forecaster's own chance of this, stated with the estimate: 80%); the middle value sits exactly at the limit.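

In this assay compound 3 and compound 4 each give only a limit and not a number, so no size can be read for the step of methoxy in place of fluoro. The compounds shown leave open what exact value any of them has, and whether they differ at all: the limit of > 50000 nM in this assay, at which 4 of the 4 values shown sit.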